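The compounds below may be only part of what the source reports. "The series", "measured", "known", "first", "only" and "open" are said of these compounds alone.

In a functional assay on QGY7701 cells (Homo sapiens) for cytotoxicity, read by MTT assay, with a stated time of 48 h (on this read-out higher numbers stand for weaker inhibition and lower numbers for stronger inhibition), compound 1 `O=c1ccoc2cc(OCc3cn(Cc4ccc(Cl)cc4Cl)nn3)ccc12` gives 13300 nM. Compound 2 `O=c1ccoc2cc(OCc3cn(Cc4cccc(F)c4)nn3)ccc12` reaches only a limit of this assay, namely > 100000 nM. Compound 3 `N#Cc1ccc(Cn2cc(COc3ccc4c(=O)ccoc4c3)nn2)cc1` likewise reaches only a limit of this assay, namely > 100000 nM. Going by these compounds, compound 3 therefore stands at the limit of > 100000 nM in this assay, at which 2 of the 3 values shown sit, and its true number is unknown. From compound 1 the two measured steps run an at least 7.5-fold higher number from compound 1 to compound 2 (0.87 log units; beyond the scatter) and an at least 7.5-fold higher number from compound 1 to compound 3 (0.87 log units; beyond the scatter), while between the two limit compounds a step that the two limits leave unreadable from compound 2 to compound 3.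

Compound 4 `N#Cc1cccc(Cn2cc(COc3ccc4c(=O)ccoc4c3)nn2)c1` differs from compound 3 by 3-cyanophenyl in place of 4-cyanophenyl on a saturated chain carbon bound to an aromatic nitrogen. Going by the values given here, no measured step exchanges 4-cyanophenyl for 3-cyanophenyl, so the measured steps give no direct guide; what they show is that both replacements of the 2,4-dichlorophenyl group sit at the limit in this assay. For compound 4 the expected step is a number no higher from compound 3 to compound 4 (the limit leaves the size open), not beyond the scatter, with the number most likely again reported only as a limit. Compound 4 is thus estimated to give 100000 nM in this assay, within 30000 nM to 300000 nM.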

Compound 4, half-maximal inhibitory concentration: 24400 nM
Estimate against measurement, compound 4: 4.1-fold (0.61 log units) above, and the stated range ends above it.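

In this assay the same atoms joined differently give different results: 3-cyanophenyl in place of 4-cyanophenyl gives an at least 4.0-fold lower number from compound 3 to compound 4 (0.61 log units; beyond the scatter). Cyano in place of fluoro on an aromatic carbon also counts, with an at least 4.0-fold lower number from compound 2 to compound 4 (0.61 log units; beyond the scatter). The 2,4-dichlorophenyl group is also no longer alone in giving a number rather than a limit, for 3-cyanophenyl in its place gives a 1.8-fold higher number from compound 1 to compound 4 (0.26 log units; within the scatter), which does not separate the two groups.

How far compound 2 and compound 3 truly lie from compound 4 stays open, and the step between compound 2 and compound 3 cannot be read, since each gives only a limit: the limit of > 100000 nM in this assay, at which 2 of the 4 values shown sit. The compounds shown also leave open how a carboxylic acid or an amine in place of the cyano group, or a longer chain on the aromatic nitrogen, would read.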